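Swapping an oxazole for an allyl on the amide nitrogen

The compounds below may be only part of what the source reports. "The series", "measured", "known", "first", "only" and "open" are said of these compounds alone.

Of the compounds shown here, three have been tested so far in an assay on HEK293 cells for agonist activity at transient receptor potential cation channel subfamily M member 8 (Homo sapiens), read by fluorescence and calcium flux, with a stated time of 15 min; a lower number here means that less compound is needed, a higher number that more compound is needed for the effect. Compound 1 `Cc1ccc(OCC(=O)N(Cc2cccs2)c2ncco2)cc1` gives 0.3 nM, the lowest number of the three. Compound 3 `CCN(Cc1cccs1)C(=O)COc1ccc(C)cc1O` gives 8 nM, a number that stands above compound 1 by more than the usual scatter, and compound 2 `Cc1ccc2oc(C(=O)N(Cc3cccs3)c3ccn[nH]3)cc2c1` gives 40 nM, the highest of the set.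

The next compound, compound 4 `C=CCN(Cc1cccs1)C(=O)COc1ccc(C)cc1`, keeps the core of compound 1 and changes one place: allyl in place of 1,3-oxazol-2-yl on an amide-type nitrogen. Its value in this assay is not yet known.

Among the measured compounds, the only one without a ring on the amide-type nitrogen is compound 3, and compound 3 gives 8 nM, well above compound 1. On that basis compound 4 is expected to need more compound than compound 1, with a step of a 17-fold higher number from compound 1 to compound 4 (1.22 log units; beyond the scatter) that lies beyond the scatter. The estimate for compound 4 is 5 nM, in a range from 1 nM to 30 nM.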

Compound 4, half-maximal effective concentration: 20 nM
Compound 4: middle estimate off by 4.0-fold (0.60 log units), on the low side; measured number inside the range.
By their numbers in this assay, from the lowest: compound 1; then compound 3; then compounds 4 and 2 (each within the scatter of the next).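

Going by these compounds alone, replacing 1,3-oxazol-2-yl with allyl on the amide-type nitrogen gives a 67-fold higher number from compound 1 to compound 4 (1.82 log units; beyond the scatter) and is the first comparison here in which only one place differs. It shows that the group at this position strongly affects the number while the rest of compound 1 stays the same. The change removes a five-membered aromatic ring and its two hydrogen-bond acceptors together and brings in a chain with one double bond, and no measurement here explains the step or separates those features.

From the compounds shown here alone, it remains open whether the ring itself or its nitrogen and oxygen atoms matter, which a phenyl or thiazole group on the same nitrogen could help to separate. A saturated propyl chain in place of allyl would test whether the double bond plays any part.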